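The source may hold more compounds than are shown below. What is called first, only, known or untested is meant among the compounds shown, and "the series" means these compounds.

Compound 1 `Cc1ccc(CNc2ncnc3c2ncn3[C@@H]2O[C@H](CO)[C@@H](O)[C@H]2O)cc1`: > 166000 nM (a limit)
Compound 2 `OC[C@H]1O[C@@H](n2cnc3c(NCc4ccc(F)cc4Cl)ncnc32)[C@H](O)[C@@H]1O`: 15600 nM

Among the measured compounds shown here, in a functional assay on K562 cells (Homo sapiens) for antiproliferative activity, with a stated time of 72 h (a lower number here means a stronger inhibitor, a higher number a weaker inhibitor), compound 2 gives 15600 nM, the only actual number so far. Compound 1 stands at the limit of > 166000 nM in this assay, at which 1 of the 2 values shown sits; this is a limit and not a number.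

Compound 3 `Cc1ccc(O)c(CNc2ncnc3c2ncn3[C@@H]2O[C@H](CO)[C@@H](O)[C@H]2O)c1` carries 2-hydroxy-5-methylphenyl in place of 2-chloro-4-fluorophenyl on a saturated chain carbon bound to a nitrogen on an aromatic ring.

For the measured compounds named here, one measured step bears on this change: an at least 10-fold lower number from compound 1 to compound 2 (1.02 log units; beyond the scatter). That step introduced the 2-chloro-4-fluorophenyl group that compound 3 gives up, and compound 3 has a methyl-bearing phenyl, as compound 1 does. The hydroxy group has not been tested in this series. A move to a higher number in this assay is therefore expected, though a smaller one than that step. The expected change is a 3.2-fold higher number from compound 2 to compound 3 (0.51 log units; beyond the scatter). For compound 3 the estimated value is 50000 nM, with an expected range of 14000 nM to 170000 nM.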

Compound 3, half-maximal inhibitory concentration: 16500 nM
Estimate against measurement, compound 3: 3.0-fold (0.48 log units) above, and the stated range covers the measured number.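

In this assay, the ring on a saturated chain carbon bound to a nitrogen on an aromatic ring can change from 2-chloro-4-fluorophenyl to 2-hydroxy-5-methylphenyl with no readable effect, the step being a 1.1-fold higher number from compound 2 to compound 3 (0.02 log units; within the scatter). A methyl-bearing ring is therefore not enough to account for the weak result of compound 1, since 2-hydroxy-5-methylphenyl in place of 4-methylphenyl gives an at least 10-fold lower number from compound 1 to compound 3 (1.00 log units; beyond the scatter). The value of compound 1 is a limit and not a number: the limit of > 166000 nM in this assay, at which 1 of the 3 values shown sits.

The change from compound 1 to compound 3 combines the hydroxy group with a different methyl placement, so the two contributions cannot be separated from the compounds shown. On these data alone, it also remains open whether an amine or a carboxylic acid on this ring, or a longer chain to it, would give a lower number than compound 2 and compound 3.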